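A few compounds are considered here, and "the series" means these few. Any claim that something is new, unique, unknown or untested is made for them only; others in the source may bear on it.

In a functional assay on HCT-15 cells (Homo sapiens) for inhibition, read by MTT assay, with a stated time of 48 h (a lower number here means a stronger inhibitor, a higher number a weaker inhibitor), compound 2 `CCCCCCCCCCCCOc1cc(OCCCCCCCCCCCC)cc(C(=O)OC)c1` gives only a limit of the assay, > 1000000 nM, and so sits at a limit among the two values shown. Compound 1 `CC(C)C(=O)N(CC(=O)NCCN)c1ccc([N+](=O)[O-])c(C(F)(F)F)c1`, on a different scaffold but carrying the same (2-aminoethyl)carbamoyl tail, likewise reaches only a limit in this assay, > 100000 nM. These two bounds, the limit of > 100000 nM in this assay, at which 1 of the 2 values shown sits, and (the limit of > 1000000 nM in this assay, at which 1 of the 2 values shown sits), are all the values shown. Compound 3 `CCCCCCCCCCCCOc1cc(OCCCCCCCCCCCC)cc(C(=O)NCCN)c1` differs from compound 2 by (2-aminoethyl)amino in place of methoxy on a carbonyl carbon. Within the data shown here, with no measured step to lean on, and with compound 1 already at its limit > 100000 nM, the expected step of an at least 2.0-fold lower number from compound 2 to compound 3 (0.30 log units; that floor lies within the scatter) is near none beyond the scatter. Compound 3 is therefore estimated at 500000 nM, between 100000 nM and 3000000 nM.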

Compound 3, half-maximal inhibitory concentration: > 1000000 nM
Compound 3: no number, only a limit; the forecaster's own chance of this, stated with the estimate: 80%; middle value at least 2.0-fold (0.30 log units) from the limit.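

Compound 2 and compound 3 both reach only a limit in this assay, so no step can be read between them. What the compounds shown leave open is how strongly any of them inhibits, since no value lies inside the measurable range.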